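Swapping the outer ring for a nitrophenyl variant

The source may report more compounds than this note shows. Statements on the series, on what has been measured and on what is new or still open speak of the compounds shown alone.

In an ADME assay on BJ cells (Homo sapiens) for cytotoxicity, read by CellTiter-Glo and resazurin assay, with a stated time of 72 h (on this read-out lower numbers stand for an effect already at smaller amounts and higher numbers for an effect only at larger amounts of compound), compound 1 `CC(C)N(Cc1cccc(OCCCCCC(=O)O)c1)C(=O)c1ccc(-c2cccc(-c3ccccc3)c2)cc1` gives only a limit of the assay, > 26000 nM.
In this assay compound 2 `CC(C)N(Cc1cccc(OCCCCCC(=O)O)c1)C(=O)c1ccc(-c2ccc3c(c2)OCCO3)cc1` gives only a limit of the assay, > 21900 nM.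
In this assay compound 3 `COc1ccc(F)c(-c2ccc(C(=O)N(Cc3cccc(OCCCCCC(=O)O)c3)C(C)C)cc2)c1` gives only a limit of the assay, > 26000 nM.

Compound 3 therefore stands where its two companions stand: none of the three results is a number, each is a limit. Two of the results sit at the limit of > 26000 nM in this assay, at which 2 of the 3 values shown sit, and one sits at the limit of > 21900 nM in this assay, at which 1 of the 3 values shown sits. The steps between the measured compounds cannot be read from such limits: a step that the two limits leave unreadable from compound 1 to compound 3, a step that the two limits leave unreadable from compound 2 to compound 3 and a step that the two limits leave unreadable from compound 1 to compound 2 are all of unreadable size.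

Compound 4 `CC(C)N(Cc1cccc(OCCCCCC(=O)O)c1)C(=O)c1ccc(-c2cccc([N+](=O)[O-])c2)cc1` is the next variation in this series. It differs from compound 3 by 3-nitrophenyl in place of 2-fluoro-5-methoxyphenyl on an aromatic carbon. The three measured exchanges at this same aromatic carbon all left the read-out at a limit, so nothing in them points to a step beyond the scatter in this assay in either direction. The expected step from compound 3 to compound 4 is therefore a step that the limit leaves unreadable from compound 3 to compound 4, meaning essentially no change. Compound 4 is expected to give 40000 nM, in a range from 15000 nM to 150000 nM, and most probably the assay will again report only a limit rather than a number.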

Compound 4, half-maximal effective concentration: > 26000 nM
Compound 4 gave a limit, no number; the forecaster's own chance of this, stated with the estimate: 85%; the middle value lies beyond the limit too.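

In this assay compound 4 gives only a limit, as do compound 1, compound 2 and compound 3, so the steps from each of those three compounds to compound 4 cannot be read. The compounds shown leave open whether exchanging the outer ring changes the effect on these cells at all, and at what concentration any of the four would act.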